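Adding a Second Methyl to a Low-Toxicity Anilide

The source may report more compounds than this note shows. Statements on the series, on what has been measured and on what is new or still open speak of the compounds shown alone.

Among the measured compounds shown here, compound 2 `Cc1ccccc1NC(=O)CSc1snnc1-c1ccc(Br)cc1Br` gives the only plain number in an ADME assay on MT4 cells (Homo sapiens) for cytotoxicity, read by MTT assay, with a stated time of 5 days (on this read-out lower numbers stand for higher toxicity in this test and higher numbers for lower toxicity in this test), namely 202000 nM. Compound 1 `Cc1cccc(C)c1NC(=O)CSc1snnc1-c1ccc(Br)cc1Br` gives >= 198000 nM in this assay, which is a limit of the assay rather than a number. The step that the limit leaves unreadable from compound 1 to compound 2 therefore cannot be sized. Compound 3 `Cc1cccc(NC(=O)CSc2snnc2-c2ccc(Br)cc2Br)c1C` is not yet measured. It carries methyl in place of hydrogen on an aromatic carbon, which reads as 2-methylphenyl to 2,3-dimethylphenyl. For the measured compounds named here, the one measured step offers no readable size, so no shift beyond the usual scatter is expected. The expected step is a 1.0-fold lower number from compound 2 to compound 3 (0.00 log units; within the scatter). Compound 3 is expected at 200000 nM, between 100000 nM and 400000 nM.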

Compound 3, half-maximal cytotoxic concentration: 241000 nM
Compound 3: middle estimate off by 1.2-fold (0.08 log units), on the low side, and the stated range covers the measured number.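

In this assay, among the compounds shown here, the change from 2-methylphenyl to 2,3-dimethylphenyl gives the first readable step on this ring, a 1.2-fold higher number from compound 2 to compound 3 (0.08 log units; within the scatter), so compound 3 cannot be told apart from compound 2. A methyl placed ortho to a methyl group and meta to a large group is thus tolerated on this read-out. The steps involving compound 1 cannot be read because its value is a limit of the assay, not a number: the limit of >= 198000 nM in this assay, at which 1 of the 3 values shown sits.

From the compounds shown here alone, whether a carboxylic acid or an amine at this place would give a number clearly apart from these remains open.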